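Notes on aryl replacement at the sulfonyl sulfur

A few compounds are considered here, and "the series" means these few. Any claim that something is new, unique, unknown or untested is made for them only; others in the source may bear on it.

The series shares one core, carrying a sulfonyl-linked aryl group on the indole-type nitrogen. Compound 1 `CN(C)/C=N/N=C/c1cn(S(=O)(=O)c2ccc(F)cc2)c2cccc([N+](=O)[O-])c12` is the fluoro member; in a functional assay on HEK293 cells for inhibition of 5-hydroxytryptamine receptor 6 (Homo sapiens), read by calcium flux and cAMP accumulation, with a stated time of 10 min (a higher number here means a weaker inhibitor, a lower number a stronger inhibitor), compound 1 gives 4970 nM. For the measured compounds named here, compound 2 `CN(C)/C=N/N=C/c1cn(S(=O)(=O)c2ccc(I)cc2)c2cccc([N+](=O)[O-])c12` is the iodo member; in this assay compound 2 gives 6340 nM, the highest of the two numbers so far, with compound 1 as its nearest neighbour. Going by the values given here, the only measured step, a 1.3-fold higher number from compound 1 to compound 2 (0.11 log units; within the scatter), shows that exchanging one halogen for another at that aromatic carbon leaves the number essentially where it was.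

Compound 3 `CN(C)/C=N/N=C/c1cn(S(=O)(=O)c2cccc3ccccc23)c2cccc([N+](=O)[O-])c12` carries a larger aryl group at the same position: naphthalen-1-yl in place of 4-iodophenyl on a sulfonyl sulfur. Among the compounds with values here, no measured step exchanges a single aromatic ring for a fused pair at the sulfonyl sulfur, so the halogen step of compound 1 to compound 2 bears on it only loosely, and the direction of any change is open. The expectation for compound 3 in this assay is therefore anchored on the value of compound 2, giving an estimated 4500 nM within a broad range of 1200 nM to 15000 nM. This estimate corresponds to a step of a 1.4-fold lower number from compound 2 to compound 3 (0.15 log units; within the scatter), expected to stay near the scatter.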

Compound 3, half-maximal inhibitory concentration: 2960 nM
The estimate for compound 3 lay 1.5-fold (0.18 log units) above the measured number, within the range that was stated.
By their numbers in this assay, from the lowest: compounds 3, 1 and 2 (each within the scatter of the next, the first and the last beyond it).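

In this assay, for the compounds shown here, the exchange of a single aromatic ring for a fused pair at the sulfonyl sulfur produces the first step to pass the scatter, a modest one (a 2.1-fold lower number from compound 2 to compound 3 (0.33 log units; beyond the scatter)), whereas the halogen exchange between the two phenyl members did not. Set against the fluoro member, the same naphthalen-1-yl group stays within the scatter (a 1.7-fold lower number from compound 1 to compound 3 (0.23 log units; within the scatter)), so the reading of this change depends on which 4-halophenyl group it replaces, and only the comparison with 4-iodophenyl supports a real difference. Nothing measured on these compounds explains either step.

From the compounds shown here alone, the three compounds hold only carbon-only aromatic groups on the sulfonyl sulfur, so it stays open whether a pyridine ring there, or a phenyl ring carrying an amine or a carboxylic acid, would move the number further in either direction. Going by these compounds, whether the step to naphthalen-1-yl would hold on a shared core with the nitro group replaced by another group also stays open.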